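From 3-methoxybenzyl to 4-chlorobenzyl at an assay limit

The source may report more compounds than this note shows. Statements on the series, on what has been measured and on what is new or still open speak of the compounds shown alone.

Measured in an ADME assay on J774.1 cells (Mus musculus) for cytotoxicity, with a stated time of 48 h; a higher number here means that more compound is needed for the effect, a lower number that less compound is needed:
- compound 1 `COC(=O)C1=C(O)C[C@H](c2ccccn2)N(Cc2cccc(OC)c2)[C@@H]1c1ccccn1` gives > 100 uM
- compound 2 `CC[C@@H]1CC2(C[C@@H](CC)N1)C(=O)NC(=O)N2Cc1ccccc1` gives > 100 uM

Compound 1 stands at > 100 uM, which is a limit of this assay and not a number. The two measured compounds give no number to compare, only (the limit of > 100 uM in this assay, at which 2 of the 2 values shown sit). Compound 3 `COC(=O)C1=C(O)C[C@H](c2ccccn2)N(Cc2ccc(Cl)cc2)[C@@H]1c1ccccn1` keeps the core of compound 1 and changes one group: 4-chlorophenyl in place of 3-methoxyphenyl on a saturated chain carbon bound to an amine nitrogen in a ring. Among the compounds with values here, no measured pair shows what such a swap does, so in this assay no step beyond the scatter is expected, in either direction. The estimated change is a number no higher from compound 1 to compound 3 (the limit leaves the size open). Compound 3 is expected at 100 uM, within an estimated range of 45 uM to 200 uM.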

Compound 3, concentration for half-maximal effect: 32.8 uM
Beside the measured number, compound 3's estimate is 3.0-fold (0.48 log units) above it, outside the stated range (below it).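

In this assay, 4-chlorobenzyl in place of 3-methoxybenzyl gives an at least 3.0-fold lower number from compound 1 to compound 3 (0.48 log units; beyond the scatter). For compound 1, > 100 uM is a limit and not a number. Compound 3 therefore shows what compound 1 could not: with the shared core kept, a change on a saturated chain carbon bound to an amine nitrogen in a ring can bring the read-out within the measurable range.

From the compounds shown here alone, the full size of the step remains unknown. Going by these compounds, it is also open whether the step follows the chlorine or the loss of the methoxy group, and whether 4-fluorobenzyl or 4-methoxybenzyl on the same core would lower the number too.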